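Methoxy addition on the aryl ring: cytotoxicity working notes

The source may report more compounds than this note shows. Statements on the series, on what has been measured and on what is new or still open speak of the compounds shown alone.

Measured so far:
compound 1 `C[C@@H]1CC[C@@H]2[C@@H](C1)O[C@@H](c1ccccc1)CC2(C)O`: 580000 nM
compound 2 `COc1cccc([C@H]2CC(C)(O)[C@@H]3CC[C@@H](C)C[C@H]3O2)c1OC`: > 937000 nM
compound 3 `COc1ccc(OC)c([C@H]2CC(C)(O)[C@@H]3CC[C@@H](C)C[C@H]3O2)c1`: 512000 nM

All three share the same core and differ only in the substitution of the six-membered aromatic ring. In an ADME assay on MDCK cells (Canis lupus familiaris) for cytotoxicity, read by MTT assay, with a stated time of 48 h (on this read-out lower numbers stand for higher toxicity in this test and higher numbers for lower toxicity in this test), compound 1 gives 580000 nM and compound 3 gives 512000 nM; these two numbers lie within the usual scatter of each other, so no order can be read between them. For compound 2 the assay reports no number but a limit, > 937000 nM. Compound 2 therefore stands at the limit of > 937000 nM in this assay, at which 1 of the 3 values shown sits, and its true position beyond that is not known.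

Compound 4 `COc1ccc([C@H]2CC(C)(O)[C@@H]3CC[C@@H](C)C[C@H]3O2)c(OC)c1OC` has not been measured. It differs from compound 2 by methoxy in place of hydrogen on an aromatic carbon. Among the compounds with values here, no pair of measured compounds differs in one place, so no measured step exists to lean on. Within the data shown here, the three values known so far sit close together, and the added group is small; the expected step is an at least 1.1-fold lower number from compound 2 to compound 4 (0.04 log units; that floor lies within the scatter), that is none beyond the scatter. Compound 4 is estimated at 850000 nM, with a range from 400000 nM to 1500000 nM, and a limit rather than a number is a real possibility.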

Compound 4, half-maximal cytotoxic concentration: > 857000 nM
Compound 4: no number, only a limit; the forecaster's own chance of this, stated with the estimate: 50%; at least 1.0-fold (0.00 log units) between middle value and limit.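

In this assay compound 4 gives > 857000 nM as a limit, not a number. Compound 2 likewise gives > 937000 nM as a limit. Within the data shown here, no step can therefore be read between compound 2 and compound 4. Still open, as far as these compounds go, is whether methoxy in place of hydrogen on an aromatic carbon moves the read-out at all.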